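The compounds below may be only part of what the source reports. "The series", "measured", "known", "first", "only" and "open" are said of these compounds alone.

Measured so far in an assay on isolated protein for displacement of a labelled ligand from Motilin receptor (Homo sapiens); on this read-out lower numbers stand for stronger inhibition and higher numbers for weaker inhibition: compound 1 `CCC[C@@H]1NC(=O)[C@@H](C(C)C)NC(=O)[C@@H](Cc2ccccc2)NCCOc2ccccc2CCCNC1=O` gives 57 nM; compound 2 `CCC[C@@H]1NC(=O)[C@@H](C(C)C)NC(=O)[C@@H](CC2CCCCC2)NCCOc2ccccc2CCCNC1=O` gives 3250 nM; compound 3 `CCC[C@@H]1NC(=O)[C@@H](C(C)C)NC(=O)[C@@H](CCc2ccccc2)NCCOc2ccccc2CCCNC1=O` gives 1490 nM.

Compound 3 stands second highest of the three numbers in this assay, close to compound 2 and far from compound 1; the steps of a 2.2-fold lower number from compound 2 to compound 3 (0.34 log units; beyond the scatter) and a 26-fold higher number from compound 1 to compound 3 (1.42 log units; beyond the scatter) place it.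

The change to compound 4 `CCC[C@@H]1NC(=O)[C@@H](C(C)C)NC(=O)[C@@H](Cc2ccc3ccccc3c2)NCCOc2ccccc2CCCNC1=O` is naphthalen-2-yl in place of benzyl on a saturated chain carbon bound to a saturated ring carbon. It puts an aromatic ring back directly on the chain carbon, which is the arrangement of compound 1. For the measured compounds named here, the steps that bear on it run the other way: a 26-fold higher number from compound 1 to compound 3 (1.42 log units; beyond the scatter) and a 57-fold higher number from compound 1 to compound 2 (1.76 log units; beyond the scatter) both show a large loss when the aromatic ring is no longer bound straight to that carbon, or is replaced by a saturated ring. A second fused aromatic ring is not covered by any measured pair, so the size of the return is uncertain, but a large step toward lower numbers in this assay is expected.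

Compound 4 is therefore estimated at 110 nM (range 20 nM to 600 nM), an expected step of a 14-fold lower number from compound 3 to compound 4 (1.13 log units; beyond the scatter).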

Compound 4, inhibition constant: 79 nM
Compound 4: middle estimate off by 1.4-fold (0.14 log units), on the high side, within the range that was stated.
By their numbers in this assay, from the lowest: compounds 1 and 4 (each within the scatter of the next); then compound 3; then compound 2.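

In this assay, naphthalen-2-yl on a saturated chain carbon bound to a saturated ring carbon stands level with the phenyl of compound 1 (a 1.4-fold higher number from compound 1 to compound 4 (0.14 log units; within the scatter)), so this position accepts a second fused aromatic ring with no change beyond the scatter. The same group restores what benzyl and cyclohexyl gave up (a 19-fold lower number from compound 3 to compound 4 (1.28 log units; beyond the scatter); a 41-fold lower number from compound 2 to compound 4 (1.61 log units; beyond the scatter)), and since naphthalen-2-yl has more heavy atoms than benzyl, heavy-atom count alone does not order these compounds. Nothing at hand accounts for this behaviour.

The compounds shown leave open whether naphthalen-1-yl would stay level with compound 1 (57 nM). Also open, from the compounds shown here alone, is what an amine or a carboxylic acid on the aromatic ring would do, and how a longer chain ending in naphthalen-2-yl would compare with compound 3.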